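The source may report more compounds than this note shows. Statements on the series, on what has been measured and on what is new or still open speak of the compounds shown alone.

Measured compounds and their values in an assay on CHO cells for displacement of a labelled ligand from adenosine receptor A3 (Homo sapiens), read by scintillation counting, tested at 10 uM; on this read-out lower numbers stand for less inhibition and higher numbers for more inhibition at the one concentration tested (going by the name of the read-out):

Compound 1, `CC(C)(C)Cc1c(-c2ccncc2)sc(N)c1C(=O)c1ccc(Cl)cc1`: 6%
Compound 2, `CC(C)(C)Cc1c(-c2ccc(F)cc2F)sc(N)c1C(=O)c1ccc(Cl)cc1`: 1%
Compound 3, `CC(C)(C)Cc1c(-c2c(F)cccc2F)sc(N)c1C(=O)c1ccc(Cl)cc1`: 1%

All three share a core that differs only in the aryl group on the aromatic carbon of the thiophene ring. Compound 3 stands level with compound 2 at the digits reported, and the step of no change at the digits printed from compound 2 to compound 3 (within the scatter) shows no movement at all. Going by the values given here, its only separation is from compound 1, and the step of a number 5 percentage points lower from compound 1 to compound 3 (within the scatter) stays within the scatter, so none of the three is told apart by this assay.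

Compound 4, `CC(C)(C)Cc1c(-c2ccc(Cl)cc2)sc(N)c1C(=O)c1ccc(Cl)cc1`, has not yet been measured. It differs from compound 3 in one place: 4-chlorophenyl in place of 2,6-difluorophenyl on an aromatic carbon. Every measured step touches this same aromatic carbon: a number 5 percentage points lower from compound 1 to compound 2 (within the scatter), a number 5 percentage points lower from compound 1 to compound 3 (within the scatter) and no change at the digits printed from compound 2 to compound 3 (within the scatter). Each of them lies within the scatter, whether a pyridinyl or either difluorophenyl group sits there. The change to 4-chlorophenyl is of the same kind, another aryl group at the same place, and nothing in the measured steps suggests any size of movement beyond the scatter.

Compound 4 is therefore expected to remain at the same low level, with an estimated step of a number 1 percentage points higher from compound 3 to compound 4 (within the scatter). The estimate for compound 4 is 2%, in a range from 0% to 10%.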

Compound 4, a percentage reported as inhibition, at one concentration (the size of the read-out at that concentration, not a potency): 1%
The estimate for compound 4 lay 1 percentage points above the measured number, within the range that was stated.
By their numbers in this assay, from the lowest: compounds 2, 3, 4 and 1 (each within the scatter of the next).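

In this assay, 4-chlorophenyl on the aromatic carbon next to the ring sulfur gives no change at the digits printed from compound 3 to compound 4 (within the scatter) and no change at the digits printed from compound 2 to compound 4 (within the scatter) and also a number 5 percentage points lower from compound 1 to compound 4 (within the scatter) and so does not set compound 4 apart from any of the other three. Going by these compounds alone, until this result, the aryl groups at this carbon carried only fluorine or a ring nitrogen, so it extends the series to a chlorine-bearing phenyl ring and shows that the read-out in this assay stays within the scatter with this group as well. No measurement at hand offers an explanation for this outcome.

From the compounds shown here alone, all four compounds carry a six-membered aromatic ring at this carbon, and their numbers lie so close together that the shared core gives no sign of which changes matter, so it remains open whether a piperidine, a carboxylic acid or a longer alkyl chain at this carbon would move the number beyond the scatter. Going by these compounds, the neopentyl group, the amino group and the (4-chlorophenyl)carbonyl group are the same throughout, so what a change at any of those places would do also remains open.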